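Lengthening the alkoxy group from compound 3 to compound 4

The compounds below may be only part of what the source reports. "The series", "measured", "known", "first", "only" and "open" are said of these compounds alone.

Compound 3 `CCc1cccc2c(OC)c(-c3occ(C)c3CO)ccc12` gives 7.1 ug/mL in a functional assay on KB cells (Homo sapiens) for cytotoxicity, read by MTT assay, with a stated time of 72 h (a higher number here means that more compound is needed for the effect, a lower number that less compound is needed), the highest of the two numbers measured here. Compound 2 `CCOc1c(-c2occ(C)c2C(=O)OC)ccc2c(CC)cccc12` gives 1.8 ug/mL in this assay. Compound 1 `CCOc1c(-c2occ(C)c2C(=O)O)ccc2c(CC)cccc12` reaches only a limit in this assay, > 10 ug/mL, which is the limit of > 10 ug/mL in this assay, at which 1 of the 3 values shown sits, and not a number. Among the compounds with values here, the one measured step, an at least 5.5-fold lower number from compound 1 to compound 2 (0.74 log units; beyond the scatter), concerns the acid-to-ester change and says nothing about the alkoxy group. Compound 4 `CCOc1c(-c2occ(C)c2CO)ccc2c(CC)cccc12` differs from compound 3 by methyl in place of hydrogen on a saturated chain carbon bound to an oxygen on an aromatic ring, a methoxy becoming an ethoxy. Within the data shown here, no measured step covers this change, so the expected step is one not beyond the scatter, a 1.2-fold lower number from compound 3 to compound 4 (0.07 log units; within the scatter). Compound 4 is therefore estimated at 6 ug/mL in this assay, expected to lie within 2.5 ug/mL to 14 ug/mL.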

Compound 4, concentration for half-maximal effect: > 10 ug/mL
Compound 4: no number, only a limit; the forecaster's own chance of this, stated with the estimate: 20%; middle value at least 1.6-fold (0.22 log units) away from the limit.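

Compound 4 gives only a limit, not a number, in this assay: the limit of > 10 ug/mL in this assay, at which 2 of the 4 values shown sit. Methoxy becoming ethoxy brings an at least 1.4-fold higher number from compound 3 to compound 4 (0.14 log units; that floor lies within the scatter), so this small lengthening is not shown to cost activity, but a larger loss remains possible. With the ethoxy kept, hydroxymethyl in place of methoxycarbonyl on this aromatic carbon brings an at least 5.5-fold higher number from compound 2 to compound 4 (0.74 log units; beyond the scatter), so the methyl ester gives a real number where the alcohol does not.

The step between the acid and the alcohol cannot be read, as both values are limits. As far as these compounds go, how a longer chain such as propoxy on that oxygen, or an amide on that aromatic carbon, would fare stays open.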